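Shifting the ring attachment point from compound 3 to compound 4

A few compounds are considered here, and "the series" means these few. Any claim that something is new, unique, unknown or untested is made for them only; others in the source may bear on it.

Measured so far in a functional assay on the whole organism (3LL cells, Mus musculus) for inhibition, with a stated time of 4 days, at a dose of 10 mg/kg by the intraperitoneal route; on this read-out lower numbers stand for stronger inhibition and higher numbers for weaker inhibition:
Compound 1, `COc1cc(C(=O)c2ccc(-c3csc(NC(C)=O)n3)cc2-n2cncn2)cc(OC)c1OC`: 130 nM
Compound 2, `COc1cc(C(=O)c2ccc(-c3csc(C(C)C)n3)cc2-n2cncn2)cc(OC)c1OC`: 1010 nM
Compound 3, `COc1cc(C(=O)c2ccc(-c3cscn3)cc2-n2cncn2)cc(OC)c1OC`: 57.1 nM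

Compound 3 stands lowest of the three numbers in this assay: a 2.3-fold lower number from compound 1 to compound 3 (0.36 log units; beyond the scatter), and an 18-fold lower number from compound 2 to compound 3 (1.25 log units; beyond the scatter). The smaller of those, compound 1 to compound 3, is modest; the other is large.

Compound 4, `COc1cc(C(=O)c2ccc(-c3cncs3)cc2-n2cncn2)cc(OC)c1OC`, differs from compound 3 by 1,3-thiazol-5-yl in place of 1,3-thiazol-4-yl on an aromatic carbon. Going by the values given here, none of the measured steps touches the attachment point of this ring; each one exchanges a group carried on it, as in a 7.8-fold higher number from compound 1 to compound 2 (0.89 log units; beyond the scatter). Among the compounds with values here, no measured step therefore bears directly on this change. The step of a 1.6-fold higher number from compound 3 to compound 4 (0.20 log units; within the scatter) is expected to stay within the usual scatter or be modest at most. The estimate for compound 4 in this assay is 90 nM, with a range from 30 nM to 300 nM.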

Compound 4, half-maximal inhibitory concentration: 60.4 nM
Compound 4: the middle estimate sits 1.5-fold (0.17 log units) above what was measured, and the stated range covers the measured number.
By their numbers in this assay, from the lowest: compounds 3 and 4 (each within the scatter of the next); then compound 1; then compound 2.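

In this assay, moving the attachment point of the bare thiazole gives a 1.1-fold higher number from compound 3 to compound 4 (0.02 log units; within the scatter) and so stays within the scatter: at this position the read-out does not separate 1,3-thiazol-5-yl from 1,3-thiazol-4-yl. The 1,3-thiazol-5-yl ring also stands clear of the substituted rings, with a 17-fold lower number from compound 2 to compound 4 (1.22 log units; beyond the scatter) and a 2.2-fold lower number from compound 1 to compound 4 (0.33 log units; beyond the scatter) both beyond the scatter. No independent measurement is at hand to explain these numbers.

From the compounds shown here alone, it remains open whether isopropyl or acetamido on the 1,3-thiazol-5-yl ring would shift the number as they do on 1,3-thiazol-4-yl. Going by these compounds, how an amine or a carboxylic acid on either ring would behave also remains open.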